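The compounds below may be only part of what the source reports. "The series", "measured", "known", "first", "only" and "open" are said of these compounds alone.

Among the measured compounds shown here, in a functional assay on MCF7 cells (Homo sapiens) for inhibition, read by MTT assay (a lower number here means a stronger inhibitor, a higher number a weaker inhibitor), three compounds have numbers so far: compound 1 (`O=C(CCCCCCC(=O)Nc1nnc(-c2ccco2)s1)NO`) gives 880 nM, compound 3 (`O=C(CCCCCCC(=O)Nc1nnc(-c2cccs2)s1)NO`) gives 880 nM, and compound 2 (`O=C(COc1ccc(C(=O)/C=C/c2ccccc2)cc1)NO`) gives 620 nM as its result. These three values lie within the scatter of one another, so compound 2 stands level with the other two, and no order can be read among them, even though its structure differs widely from theirs.

The next compound, compound 4 (`O=C(COc1ccc(C(=O)/C=C/c2ccc(F)cc2)cc1)NO`), alters compound 2 in a single place (fluoro in place of hydrogen on an aromatic carbon). A fluoro takes the place of hydrogen on an aromatic carbon, so phenyl becomes 4-fluorophenyl.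

For the measured compounds named here, no measured step shows this exact change. Going by the values given here, the one available step comes from a different core and a different swap (no change at the digits printed from compound 1 to compound 3 (within the scatter)), which makes it only a loose guide. Still, it shows one small replacement on an aromatic carbon leaving the number where it was. The step expected here (a 1.0-fold lower number from compound 2 to compound 4 (0.01 log units; within the scatter)) is therefore no larger than the scatter, with no firm direction. Among the compounds with values here, this expectation starts from compound 2 at 620 nM and allows a wide margin, since only one step supports it. Compound 4 is estimated at 600 nM, with an expected range from 230 nM to 1500 nM in this assay once measured.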

Compound 4, half-maximal inhibitory concentration: 620 nM
Estimate against measurement, compound 4: 1.0-fold (0.01 log units) below, and the stated range covers the measured number.
By their numbers in this assay, from the lowest: compounds 2, 4, 1 and 3 (each within the scatter of the next).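

In this assay, placing fluoro on an aromatic carbon para to a large group, which turns phenyl into 4-fluorophenyl, gives no change at the digits printed from compound 2 to compound 4 (within the scatter). Among the compounds shown here, this is the first direct reading at this position, and it shows that adding one fluorine atom to the ring of compound 2 leaves the result level with the parent, whereas the earlier compounds offered only a swap of one ring for another on the core of compound 1. Both single-place steps shown now end within the scatter, and neither goes against the other, though two small replacements on two different cores make a thin basis for any wider pattern, and no information at hand gives a reason for this outcome.

On these data alone, one fluorine atom is also only a small probe of this position, so it remains open whether an amine, a methoxy group or a carboxylic acid in the same place would leave the number equally level. As far as these compounds go, it also remains open whether a fluoro on the aromatic part of compound 1 would behave as it does on compound 2.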